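The source may report more compounds than this note shows. Statements on the series, on what has been measured and on what is new or still open speak of the compounds shown alone.

Of the compounds shown here, two have been tested so far in an ADME assay on HepG2 cells (Homo sapiens) for cytotoxicity, read by MTT assay, with a stated time of 72 h; on this read-out lower numbers stand for higher toxicity in this test and higher numbers for lower toxicity in this test. Compound 1 `Clc1ccccc1/C=N/c1sc2c(c1-c1nc3ccccc3s1)CCC2` gives 180 ug/mL in this assay. Compound 2 `Clc1ccc(/C=N/c2sc3c(c2-c2nc4ccccc4s2)CCCC3)c(Cl)c1` gives 384 ug/mL in this assay, the higher of the two numbers; the gap between compound 2 and compound 1 lies beyond the usual scatter of this test, so compound 2 is the less toxic of the two on this read-out. The two compounds differ from each other in more than one place, so the two values alone do not say what each difference contributes.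

Compound 3 `O=[N+]([O-])c1ccccc1/C=N/c1sc2c(c1-c1nc3ccccc3s1)CCCC2` has not yet been measured. It differs from compound 2 in a single place: 2-nitrophenyl in place of 2,4-dichlorophenyl on a carbon with a double bond to nitrogen. Going by the values given here, no measured pair in the set shows what such an exchange does to the half-maximal cytotoxic concentration, so neither direction is favoured by the data. The expected step is therefore a 1.3-fold lower number from compound 2 to compound 3 (0.11 log units; within the scatter), a change no larger than the scatter, with no clear direction. Compound 3 is accordingly estimated at 300 ug/mL in this assay, with a likely range from 150 ug/mL to 600 ug/mL.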

Compound 3, half-maximal cytotoxic concentration: 393 ug/mL
Compound 3: the middle estimate sits 1.3-fold (0.12 log units) below what was measured; measured number inside the range.
By their numbers in this assay, from the lowest: compound 1; then compounds 2 and 3 (each within the scatter of the next).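

In this assay, going by these compounds alone, the exchange of 2,4-dichlorophenyl for 2-nitrophenyl on a carbon with a double bond to nitrogen gives a 1.0-fold higher number from compound 2 to compound 3 (0.01 log units; within the scatter) and is the first step that changes one place only, so on this read-out compound 2 and compound 3 cannot be told apart. At this place, then, the two chlorine atoms of the leaving group can give way to a nitro group, with its 2 hydrogen-bond acceptors where the leaving group has 0, without a change in the half-maximal cytotoxic concentration that stands out from the scatter. No measurement at hand speaks to why these two different groups give matching numbers, so this remains an observation on a single pair.

From the compounds shown here alone, whether this tolerance extends to other groups at this place, such as a phenyl ring carrying an amine or a carboxylic acid, or a plain methyl in place of the ring, remains open. Also open, going by these compounds, is how much of the gap between compound 1 and compound 2 belongs to each of the places in which they differ.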